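The source may hold more compounds than are shown below. What is called first, only, known or untested is meant among the compounds shown, and "the series" means these compounds.

Working notes on the series. Compound 2 `Cc1nn(C2COC2)cc1Nc1nc(N)c2c(C#N)c(N3CCC[C@H]3C)n(C)c2n1` gives 240 nM in an assay on HEK293 cells for inhibition of Leucine-rich repeat serine/threonine-protein kinase 2 (Homo sapiens), with a stated time of 48 h (on this read-out higher numbers stand for weaker inhibition and lower numbers for stronger inhibition), the lowest of the three numbers measured, though its neighbours sit within the scatter of it: compound 3 `Cc1nn(CC(C)(C)O)cc1Nc1nc(N)c2c(C#N)c(N3CCC[C@H]3C)n(C)c2n1` gives 280 nM and compound 1 `Cc1c(Nc2nc(N)c3c(C#N)c(N4CCC[C@H]4C)n(C)c3n2)cnn1C` gives 310 nM. The two recorded steps, a 1.3-fold lower number from compound 1 to compound 2 (0.11 log units; within the scatter) and a 1.2-fold higher number from compound 2 to compound 3 (0.07 log units; within the scatter), both alter the substitution of the pyrazole and both stay within the scatter. Compound 4 `C[C@@H]1CCCN1c1c(C#N)c2c(N)nc(Nc3cn(C)nc3Cl)nc2n1C` is the next member; the change from compound 2 is 3-chloro-1-methyl-1H-pyrazol-4-yl in place of 3-methyl-1-(oxetan-3-yl)-1H-pyrazol-4-yl on a nitrogen on an aromatic ring. Both measured steps bear on it in that they swap groups on the same pyrazole, yet neither introduces a chlorine, so no guidance exists for that part. No step beyond the scatter is expected in this assay, and compound 4 is estimated at 300 nM (range 120 nM to 750 nM), a step of a 1.3-fold higher number from compound 2 to compound 4 (0.10 log units; within the scatter).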

Compound 4, half-maximal inhibitory concentration: 190 nM
Compound 4: the middle estimate sits 1.6-fold (0.20 log units) above what was measured; low and high end bracket the measured number.
By their numbers in this assay, from the lowest: compounds 4, 2, 3 and 1 (each within the scatter of the next).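

In this assay, going by these compounds alone, 3-chloro-1-methyl-1H-pyrazol-4-yl, the first chlorine-bearing group, gives steps that stay within the scatter, both against the oxetane-bearing group (a 1.3-fold lower number from compound 2 to compound 4 (0.10 log units; within the scatter)) and against the dimethyl group (a 1.6-fold lower number from compound 1 to compound 4 (0.21 log units; within the scatter)). The number therefore holds across a group with fewer heavy atoms and one ring fewer than 3-methyl-1-(oxetan-3-yl)-1H-pyrazol-4-yl. Nothing on hand gives a reason for these steps.

Compound 4 differs from compound 2 at both pyrazole substituents, so the chlorine and the methyl on nitrogen cannot be read apart. Also open, from the compounds shown here alone, is whether a bromine, a nitrile or a methoxy group in place of the chlorine would leave the number within the scatter.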